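Replacing Trifluoromethyl with Methoxy

The source may report more compounds than this note shows. Statements on the series, on what has been measured and on what is new or still open speak of the compounds shown alone.

For the measured compounds named here, in an ADME assay on HeLa cells (Homo sapiens) for cytotoxicity (a higher number here means that more compound is tolerated, a lower number that less compound is tolerated), compound 2 `C[C@@H](NC(=O)c1nc(-c2cc(C(F)(F)F)ccn2)nc(O)c1O)C1CCCCC1` gives 6000 nM, the higher of the two numbers so far, while compound 1 `Cc1ccnc(-c2nc(O)c(O)c(C(=O)N[C@H](C)C3CCCCC3)n2)c1` gives 2700 nM. Compound 3 `COc1ccnc(-c2nc(O)c(O)c(C(=O)N[C@H](C)C3CCCCC3)n2)c1` is still unmeasured and differs from compound 2 by methoxy in place of trifluoromethyl on an aromatic carbon. Going by the values given here, the only measured step that bears on this is modest: a 2.2-fold higher number from compound 1 to compound 2 (0.35 log units; beyond the scatter), with trifluoromethyl in place of methyl. A similarly modest move towards a lower number therefore seems likely, though one step is thin evidence. The expected change is a 1.9-fold lower number from compound 2 to compound 3 (0.27 log units; within the scatter). The estimate for compound 3 is 3200 nM, within a range of 1300 nM to 7500 nM.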

Compound 3, half-maximal cytotoxic concentration: 3000 nM
Beside the measured number, compound 3's estimate is 1.1-fold (0.03 log units) above it; the range from low to high includes it.
By their numbers in this assay, from the lowest: compounds 1, 3 and 2 (each within the scatter of the next, the first and the last beyond it).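

At this position, opposite the ring nitrogen, methoxy cannot be told apart from methyl in this assay: a 1.1-fold higher number from compound 1 to compound 3 (0.05 log units; within the scatter). Methoxy set against trifluoromethyl gives a 2.0-fold lower number from compound 2 to compound 3 (0.30 log units; within the scatter), so methoxy lies within the scatter of both groups, and only the step between methyl and trifluoromethyl stands beyond it. Nothing available explains these numbers. Still open, as far as these compounds go, is what an amine or a carboxylic acid at this position would give, and whether a longer chain than methoxy would stay in the same range.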